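This account rests on a few compounds, and the source may have more. Where it says the series, first, only, none or still open, it means among the compounds named here.

The series shares the core of compound 1 `CCS(=O)(=O)N[C@H]1CCCN(C(C)=O)[C@H]1CO[C@H]1CC[C@@H](C(C)C)CC1`. In a functional assay on CHO-K1 cells for agonist activity at Orexin/Hypocretin receptor type 1 (Homo sapiens), read by FLIPR and calcium flux (on this read-out lower numbers stand for an effect already at smaller amounts and higher numbers for an effect only at larger amounts of compound), compound 1 gives only a limit, > 100000 nM. Compound 2 `CCS(=O)(=O)N[C@@H]1CCCN(C(C)=O)[C@H]1CO[C@H]1CC[C@@H](C(C)C)CC1` differs from compound 1 only in configuration as drawn. In this assay compound 2 gives likewise only a limit, > 100000 nM. The step that the two limits leave unreadable from compound 1 to compound 2 stays unreadable because of the limit of > 100000 nM in this assay, at which 2 of the 2 values shown sit. Compound 3 `CC(=O)N1CCC[C@H](NS(=O)(=O)C(C)C)[C@@H]1CO[C@H]1CC[C@@H](C(C)C)CC1` carries methyl in place of hydrogen on a saturated chain carbon bound to a saturated chain carbon and a sulfonyl sulfur. Going by the values given here, no measured step bears on this change, since the one step measured is unreadable. Compound 3 is therefore expected to remain at the limit as well, estimated at 150000 nM within 30000 nM to 1000000 nM. The step that the limit leaves unreadable from compound 1 to compound 3 is expected to show nothing beyond the scatter.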

Compound 3, half-maximal effective concentration: > 100000 nM
Compound 3 ended at the assay's limit; the forecaster's own chance of this, stated with the estimate: 90%; the middle value lies beyond the limit too.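

Going by these compounds alone, no step among compound 1, compound 2 and compound 3 can be read, the change from ethyl to isopropyl included: the limit of > 100000 nM in this assay, at which 3 of the 3 values shown sit. The compounds shown leave open whether configuration or the sulfonyl substituent changes the read-out in this assay at all.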